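The source may report more compounds than this note shows. Statements on the series, on what has been measured and on what is new or still open speak of the compounds shown alone.

Measured so far:
- compound 1 `COc1ccccc1-n1nc(-c2ccc(C(F)(F)F)cc2O)nc1-c1ccccc1O` — 96.2%
- compound 2 `Oc1cc(C(F)(F)F)ccc1-c1nc(-c2ccccc2O)n(-c2cccc(C(F)(F)F)c2)n1` — 99.9%

In a functional assay on PC-12 cells (Rattus norvegicus) for cytotoxicity, read by MTT assay, with stated times of 2 h and 24 h, tested at 10 uM (a lower number here means a weaker effect, a higher number a stronger effect of the compound at the concentration tested), compound 1 gives 96.2% and compound 2 gives 99.9%. On the numbers shown compound 2 stands at the top of the two, but the gap to compound 1 is within the scatter, so the two cannot be told apart on this read-out. Among the compounds with values here, the single step on record is a number 3.7 percentage points higher from compound 1 to compound 2 (within the scatter), a swap of the aryl group on the aromatic nitrogen that left the read-out essentially unchanged.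

Compound 3 `Oc1cc(C(F)(F)F)ccc1-c1nc(-c2ccccc2O)n(-c2ccc(Cl)cc2Cl)n1` has not yet been measured. It differs from compound 2 as follows: 2,4-dichlorophenyl in place of 3-(trifluoromethyl)phenyl on an aromatic nitrogen. The step from compound 1 to compound 2 is the only one that bears on this change, as it also replaced the aryl group on the same aromatic nitrogen, and it gave a step within the scatter. Both measured compounds sit near the ceiling of the read-out, which leaves little room for a rise. The expectation for compound 3 is therefore a step no larger than the scatter, a number 2.9 percentage points lower from compound 2 to compound 3 (within the scatter). Compound 3 is estimated at 97%, with a range from 88% to 100%.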

Compound 3, a percentage reported as activity, at one concentration (the size of the read-out at that concentration, not a potency): 95.2%
Compound 3: the middle estimate sits 1.8 percentage points above what was measured; measured number inside the range.
By their numbers in this assay, from the lowest: compounds 3, 1 and 2 (each within the scatter of the next).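

In this assay, the 2,4-dichlorophenyl group on the aromatic nitrogen gives a change within the scatter against the 3-(trifluoromethyl)phenyl group (a number 4.7 percentage points lower from compound 2 to compound 3 (within the scatter)) and against the 2-methoxyphenyl group (a number 1 percentage points lower from compound 1 to compound 3 (within the scatter)). With a third substituted phenyl group and chlorine now on that ring, the three compounds still cannot be told apart, so this read-out at a single concentration does not separate these aryl groups at this position. Nothing on hand explains this lack of separation.

From the compounds shown here alone, all three compounds carry a substituted phenyl group on this nitrogen, so it remains open whether a different kind of group there, such as a benzyl group, a short alkyl chain, or a phenyl group bearing an amine or a carboxylic acid, would move the number away from the top of the scale. The 2-hydroxyphenyl and 2-hydroxy-4-(trifluoromethyl)phenyl groups are the same throughout, so the compounds shown say nothing about how the read-out responds to changes in either one.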